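Trimming a Methyl from the Ester Ring

The source may report more compounds than this note shows. Statements on the series, on what has been measured and on what is new or still open speak of the compounds shown alone.

Within the data shown here, compound 1 `CC1=CC[C@H](C(C)C)c2cc(C)c(OC(=O)c3ccc(C)cc3)cc21` stands highest of the two numbers measured so far in a functional assay on MCF7 cells (Homo sapiens) for antiproliferative activity, read by sulforhodamine B assay, with a stated time of 48 h, tested at 50 uM; a higher number here means more inhibition at the concentration tested (going by the name of the read-out), a lower number less inhibition: in this assay compound 1 gives 65%. Compound 2 `COc1cccc(C(=O)Oc2cc3c(C)ccc(C(C)C)c3cc2C)c1` gives 31.8% in this assay, a gap from compound 1 that lies beyond the usual scatter. Compound 3 `CC1=CC[C@H](C(C)C)c2cc(C)c(OC(=O)c3ccccc3)cc21` has not yet been measured. It differs from compound 1 in one place: hydrogen in place of methyl on an aromatic carbon. Among the measured compounds shown here, no measured step of this kind exists here, so a modest fall in inhibition, or none beyond the scatter, is expected, as the estimated step of a number 10 percentage points lower from compound 1 to compound 3 (within the scatter) shows. Compound 3 is estimated at 55%, likely between 35% and 75%.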

Compound 3, a percentage reported as inhibition, at one concentration (the size of the read-out at that concentration, not a potency): 60.7%
For compound 3 the middle estimate is 5.7 percentage points below the measured one; measured number inside the range.
By their numbers in this assay, from the lowest: compound 2; then compounds 3 and 1 (each within the scatter of the next).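

In this assay, this position now has its first measured step, a number 4.3 percentage points lower from compound 1 to compound 3 (within the scatter). The 4-methylphenyl to phenyl swap, para to a large group, therefore leaves inhibition at the tested concentration indistinguishable from that of the methyl-bearing ester, so this methyl is not required for the effect in this pair. No supporting measurement is available to explain this result. Still open, going by these compounds, is how an amine or a carboxylic acid on this aromatic carbon would read in this assay, and whether the same swap would read alike on a different core.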